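Chloro in Place of Methoxy: A Small Expected Step

This account rests on a few compounds, and the source may have more. Where it says the series, first, only, none or still open, it means among the compounds named here.

Among the compounds with values here, in a functional assay on PC-12 cells (Rattus norvegicus) for cytotoxicity, read by MTT assay, with a stated time of 24 h (on this read-out lower numbers stand for an effect already at smaller amounts and higher numbers for an effect only at larger amounts of compound), compound 1 `Cc1ccc(-c2nnc(-c3sc4ncnc(N5CCCCC5)c4c3C)o2)cc1` gives 28.2 ug/mL and compound 2 `COc1ccc(-c2nnc(-c3sc4ncnc(N5CCCCC5)c4c3C)o2)cc1` gives 20.1 ug/mL as the only two measured numbers, which lie within the scatter of each other. Compound 3 `Cc1c(-c2nnc(-c3ccc(Cl)cc3)o2)sc2ncnc(N3CCCCC3)c12` carries chloro in place of methoxy on an aromatic carbon. Within the data shown here, the one measured step that bears on this, methoxy in place of methyl on an aromatic carbon, is a 1.4-fold lower number from compound 1 to compound 2 (0.15 log units; within the scatter) and offers the only guide, so no step beyond the scatter is expected. The estimated step of a 1.2-fold higher number from compound 2 to compound 3 (0.08 log units; within the scatter) has no firm direction. For compound 3 the expected value is 24 ug/mL within an estimated range of 11 ug/mL to 50 ug/mL on this read-out.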

Compound 3, half-maximal effective concentration: 21.8 ug/mL
Compound 3: middle estimate off by 1.1-fold (0.04 log units), on the high side; the measured number falls inside the stated range.
By their numbers in this assay, from the lowest: compounds 2, 3 and 1 (each within the scatter of the next).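

In this assay the change from methoxy to chloro gives a 1.1-fold higher number from compound 2 to compound 3 (0.04 log units; within the scatter) and the change from methyl to chloro gives a 1.3-fold lower number from compound 1 to compound 3 (0.11 log units; within the scatter) at the same position. This adds a halogen to what the earlier pair showed: methyl, methoxy and chloro, para to a large group, all give numbers within the scatter of one another. No measurement shown offers an explanation for this. As far as these compounds go, whether an amine, a carboxylic acid or a longer chain at this position would give a number beyond the scatter remains open.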